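The source may report more compounds than this note shows. Statements on the series, on what has been measured and on what is new or still open speak of the compounds shown alone.

Among the measured compounds shown here, in a physicochemical assay for lipophilicity, at pH 7.4 (on this read-out lower numbers stand for lower lipophilicity and higher numbers for higher lipophilicity), compound 3 `CNC(=O)c1cc(C(=O)NCCC[C@H]2OC[C@H](N)CO2)cc2c1OC[C@H]2c1ccccc1` gives 2.6, the lowest of the three numbers so far. Compound 1 `CCC(=O)N1C[C@@H]2[C@H](C1)[C@H]2NC(=O)c1cc(C(=O)NC)c2c(c1)[C@H](c1ccccc1)CO2` gives 3.4 and compound 2 `CNC(=O)c1cc(C(=O)NC2CC2)cc2c1OC[C@H]2c1ccccc1` gives 3.6. Compound 4 `CNC(=O)c1cc(C(=O)N[C@H]2C[C@@H]2C)cc2c1OC[C@H]2c1ccccc1` differs from compound 3 in one place: a group of 4 heavy atoms (4 carbon; one three-membered non-aromatic ring of carbon only) in place of a group of 10 heavy atoms (7 carbon, 1 nitrogen, 2 oxygen; one six-membered non-aromatic ring with 2 hetero atoms), on an amide-type nitrogen. The group that enters is 2-methylcyclopropyl. Compound 2 also carries a carbon-only three-membered ring on that nitrogen, so the nearest guide is a number 1.00 log units lower from compound 2 to compound 3 (beyond the scatter). A second guide is a number 0.80 log units lower from compound 1 to compound 3 (beyond the scatter). Returning to a carbon-only group should reverse the direction of these steps, so a rise of similar or slightly larger size is expected in this assay. The estimated change is a number 1.30 log units higher from compound 3 to compound 4 (beyond the scatter). Compound 4 is expected at 3.9, within an estimated range of 3.5 to 4.3.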

Compound 4, distribution coefficient: 4.5
Compound 4: middle estimate off by 0.60 log units, on the low side, and the stated range ends below it.
By their numbers in this assay, from the lowest: compound 3; then compounds 1 and 2 (each within the scatter of the next); then compound 4.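

In this assay one methyl in place of hydrogen on a saturated ring carbon gives a number 0.90 log units higher from compound 2 to compound 4 (beyond the scatter) on its own, so even this small swap on the amide-type nitrogen's group moves the number. Against the larger groups, 2-methylcyclopropyl gives a number 1.90 log units higher from compound 3 to compound 4 (beyond the scatter) and a number 1.10 log units higher from compound 1 to compound 4 (beyond the scatter) here, leaving compound 4 highest of the four. Nothing measured here accounts for the size of these steps.

Still open, as far as these compounds go, is whether the other stereoisomers of 2-methylcyclopropyl would give the same number. Also open, from the compounds shown here alone, is whether an ethyl or an amine on the three-membered ring would raise or lower it.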